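The source may report more compounds than this note shows. Statements on the series, on what has been measured and on what is new or still open speak of the compounds shown alone.

Measured in a functional assay on MCF7 cells (Homo sapiens) for inhibition, with a stated time of 96 h; on this read-out higher numbers stand for weaker inhibition and lower numbers for stronger inhibition:
- Compound 1 `COc1cc(C(=O)c2cn(-c3ccc(C)cc3)cc2-c2nccs2)cc(OC)c1OC`: 14 nM
- Compound 2 `COc1cc(C(=O)c2cn(-c3ccc(F)cc3)cc2-c2nccs2)cc(OC)c1OC`: 22 nM

Going by the values given here, with only these two values, compound 1 cannot be separated from compound 2, as the one measured step, a 1.6-fold higher number from compound 1 to compound 2 (0.20 log units; within the scatter), shows. Compound 3 `COc1cc(C(=O)c2cn(-c3ccc(C)cc3)cc2-c2cccnc2)cc(OC)c1OC` has pyridin-3-yl in place of 1,3-thiazol-2-yl on an aromatic carbon. That measured step is fluoro in place of methyl at a different place, so it bears only weakly on this swap, and no measurement shows the direction. A modest, uncertain move in this assay is expected, estimated as a 2.1-fold higher number from compound 1 to compound 3 (0.33 log units; beyond the scatter). For compound 3 the estimate is 30 nM, with an expected range of 6 nM to 150 nM.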

Compound 3, half-maximal inhibitory concentration: 19 nM
For compound 3 the middle estimate is 1.6-fold (0.20 log units) above the measured one; low and high end bracket the measured number.
By their numbers in this assay, from the lowest: compounds 1, 3 and 2 (each within the scatter of the next).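

In this assay, pyridin-3-yl in place of 1,3-thiazol-2-yl gives a 1.4-fold higher number from compound 1 to compound 3 (0.13 log units; within the scatter). This position therefore accepts a six-membered aromatic ring with 1 hetero atom as well as a five-membered one with 2 hetero atoms, with no separation between the two on this read-out. No measured evidence is available to explain this result.

From the compounds shown here alone, it remains open whether a plain phenyl ring, an amine or a carboxylic acid at this place would give a similar number. Also open, going by these compounds, is whether pyridin-3-yl would behave the same way with the fluoro group of compound 2 in place of methyl.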